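Replacing One Aromatic Ring by Another on the Shared Core

A few compounds are considered here, and "the series" means these few. Any claim that something is new, unique, unknown or untested is made for them only; others in the source may bear on it.

Compound 3 `CC(C)(C)Cc1c(-c2ccccn2)sc(N)c1C(=O)c1ccc(Cl)cc1` carries a pyridin-2-yl group on the shared core. In an assay on CHO cells for displacement of a labelled ligand from adenosine receptor A1 (Homo sapiens), read by scintillation counting, tested at 10 uM (a lower number here means less inhibition, a higher number more inhibition at the concentration tested (going by the name of the read-out)), compound 3 gives 1%, level with compound 1 `CC(C)Cc1csc(N)c1C(=O)c1ccc(Cl)cc1` at 1% and with compound 2 `CC(C)(C)Cc1csc(N)c1C(=O)c1ccc(Cl)cc1` at 1%. Neither earlier step moved the read-out: no change at the digits printed from compound 1 to compound 2 (within the scatter), and no change at the digits printed from compound 2 to compound 3 (within the scatter). Compound 4 `CC(C)(C)Cc1c(-c2c(F)cccc2F)sc(N)c1C(=O)c1ccc(Cl)cc1` differs from compound 3 in one place: 2,6-difluorophenyl in place of pyridin-2-yl on an aromatic carbon. The new ring enters next to the ring sulfur, where the pyridin-2-yl stood. Of the measured steps, the one that bears on this is the attachment of the pyridin-2-yl ring, which stayed within the scatter, so the expected step of a number 1 percentage points higher from compound 3 to compound 4 (within the scatter) is none beyond the scatter. Compound 4 is therefore expected to give 2%, in the range from -8% to 12%.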

Compound 4, a percentage reported as inhibition, at one concentration (the size of the read-out at that concentration, not a potency): 1%
Beside the measured number, compound 4's estimate is 1 percentage points above it; measured number inside the range.
By their numbers in this assay, from the lowest: compounds 1, 2, 3 and 4 (each within the scatter of the next).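

At the aromatic carbon next to the ring sulfur, exchanging pyridin-2-yl, which has a ring nitrogen, for the all-carbon 2,6-difluorophenyl leaves this assay unmoved, with no change at the digits printed from compound 3 to compound 4 (within the scatter). Set against hydrogen on that carbon, the 2,6-difluorophenyl ring also gives no change at the digits printed from compound 2 to compound 4 (within the scatter), so hydrogen and both aromatic rings now read alike here. Nothing available explains this result.

On these data alone, whether any group on this carbon can move the read-out remains open. An amine or a carboxylic acid in place of the aromatic ring might behave differently.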